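The source may report more compounds than this note shows. Statements on the series, on what has been measured and on what is new or still open speak of the compounds shown alone.

In a functional assay on MCF7 cells (Homo sapiens) for cytotoxicity, read by WST assay, with a stated time of 72 h (on this read-out higher numbers stand for weaker inhibition and lower numbers for stronger inhibition), compound 1 `Cc1ccc(C2(c3ccc(O)cc3)C(=O)Nc3c2ccc(F)c3F)cc1` gives 1.7 nM, the lowest of the three numbers, while compound 3 `O=C1Nc2c(ccc(F)c2F)C1(c1ccncc1)c1ccc(O)cc1` gives 37 nM and compound 2 `COc1ccc(C2(c3cccc(O)c3)C(=O)Nc3c2ccc(F)c3F)cc1` gives 196 nM. Compound 4 `CCCC1(c2ccc(O)cc2)C(=O)Nc2c1ccc(F)c2F` carries propyl in place of 4-methylphenyl on a saturated ring carbon. Compound 2 differs from compound 1 in more than one place, so it offers no single-change comparison. Among the compounds with values here, the one measured step that bears on this change is large: a 22-fold higher number from compound 1 to compound 3 (1.34 log units; beyond the scatter), with pyridin-4-yl in place of 4-methylphenyl. Within the data shown here, no measured compound has a chain at this carbon, so the size remains uncertain. The expected move, towards a higher number, is a 24-fold higher number from compound 1 to compound 4 (1.37 log units; beyond the scatter), similar in size to that step. Compound 4 is estimated at 40 nM, within an expected range of 6 nM to 300 nM.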

Compound 4, half-maximal inhibitory concentration: > 1000 nM
Compound 4 gave a limit, no number; the forecaster's own chance of this, stated with the estimate: 3%; middle value at least 25-fold (1.39 log units) away from the limit.
By their numbers in this assay, from the lowest: compound 1; then compound 3; then compound 2. At a limit, above all of these: compound 4.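

Compound 4 gives only a limit in this assay, not a number: the limit of > 1000 nM in this assay, at which 1 of the 4 values shown sits. Replacing the aromatic ring at this saturated ring carbon with propyl gives an at least 580-fold higher number from compound 1 to compound 4 (2.76 log units; beyond the scatter), and the same replacement of pyridin-4-yl gives an at least 27-fold higher number from compound 3 to compound 4 (1.43 log units; beyond the scatter). Among these compounds, the two aromatic rings at this carbon give numbers, whereas the propyl chain gives only a limit.

On these data alone, whether a methyl group, a longer chain or a cyclohexyl ring at this carbon would give a number remains open. As far as these compounds go, how far compound 4 lies past its limit also remains unknown.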